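Sulfoxide and Sulfone Analogues Against a Lipid Kinase

A few compounds are considered here, and "the series" means these few. Any claim that something is new, unique, unknown or untested is made for them only; others in the source may bear on it.

Compound 1 `N#Cc1ccc(F)c([S+]([O-])c2nc(-c3cnn4ccc(Br)cc34)cs2)c1` and compound 2 `N#Cc1cc(S(=O)(=O)c2nc(-c3cnn4ccc(Br)cc34)cs2)ccc1F` share most of their structure, but the difference between their two cores is not broken down here. In an assay on isolated protein for inhibition of phosphatidylinositol 4,5-bisphosphate 3-kinase catalytic subunit beta isoform (Homo sapiens) (a higher number here means a weaker inhibitor, a lower number a stronger inhibitor), compound 1 reaches only a limit of the assay, > 1000 nM. In this assay compound 2 likewise gives only a limit, > 1000 nM. Compound 3 `CN(C)CCN(C)c1ccc(C#N)cc1[S+]([O-])c1nc(-c2cnn3ccc(Br)cc23)cs1` carries (2-(dimethylamino)ethyl)(methyl)amino in place of fluoro on an aromatic carbon, and in this assay compound 3 gives 4340 nM, so that a step that the limit leaves unreadable from compound 1 to compound 3 because of the limit of > 1000 nM in this assay, at which 2 of the 3 values shown sit.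

Compound 4 `CN(C)CCN(C)c1ccc(S(=O)(=O)c2nc(-c3cnn4ccc(Br)cc34)cs2)cc1C#N` is not yet measured. It carries (2-(dimethylamino)ethyl)(methyl)amino in place of fluoro on an aromatic carbon, the same kind of change as before, though here the place is ortho to a cyano group and para to a large group rather than ortho to a large group and para to a cyano group. Compound 4 is expected to give about 5000 nM in this assay, estimated between 1500 nM and 20000 nM. The expected step is a step that the limit leaves unreadable from compound 2 to compound 4, a rough guess. It rests on compound 3, which gives 4340 nM in this assay, while the step from compound 2 itself cannot be read.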

Compound 4, half-maximal inhibitory concentration: > 1000 nM
Compound 4 ended at the assay's limit; the forecaster's own chance of this, stated with the estimate: 40%; the middle value lies beyond the limit too.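

No size can be read for the change from compound 2 to compound 4, because both results are limits rather than numbers: the limit of > 1000 nM in this assay, at which 3 of the 4 values shown sit. The compounds shown leave open what replacing fluoro with (2-(dimethylamino)ethyl)(methyl)amino does on this core.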